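Bromo in place of fluoro: notes on compound 3

The source may hold more compounds than are shown below. What is called first, only, known or untested is meant among the compounds shown, and "the series" means these compounds.

Measured in a functional assay on HEp-2 cells (Homo sapiens) for cytotoxicity; on this read-out higher numbers stand for weaker inhibition and lower numbers for stronger inhibition:
- compound 1 `Nc1nc(F)nc2c1ncn2[C@H]1C[C@H](O)[C@@H](CO)O1`: 200 nM
- compound 2 `Nc1nc(Br)nc2c1ncn2C1O[C@H](CO)[C@@H](O)[C@H]1O`: 4000 nM

Only these two values are available so far. Compound 1, at 200 nM, holds the lower number and so the stronger inhibition of the pair. Compound 2 stands higher, at 4000 nM, and the gap between them lies beyond the scatter.

The next compound is compound 3 `Nc1nc(Br)nc2c1ncn2[C@H]1C[C@H](O)[C@@H](CO)O1`, which differs from compound 1 at a single place: bromo in place of fluoro on an aromatic carbon. The change is bromo in place of fluoro on an aromatic carbon, between two ring nitrogen atoms. For the measured compounds named here, no measured pair differs in one place only, so the data offer no direct precedent for this exchange, and the expectation below is loosely anchored.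

A small move to a higher number is expected in this assay, only a little beyond the scatter. The estimated change is a 2.5-fold higher number from compound 1 to compound 3 (0.40 log units; beyond the scatter). For compound 3 the expected value is 500 nM, with an estimated range of 150 nM to 1800 nM.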

Compound 3, half-maximal inhibitory concentration: 20 nM
Estimate against measurement, compound 3: 25-fold (1.40 log units) above; the whole stated range lies above it.
By their numbers in this assay, from the lowest: compound 3; then compound 1; then compound 2.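

In this assay the series now has its first comparison of compounds that differ in one place, and bromo in place of fluoro gives a 10-fold lower number from compound 1 to compound 3 (1.00 log units; beyond the scatter) on an otherwise unchanged structure. This shows that the aromatic carbon between two ring nitrogen atoms is not a silent position on this read-out: the group it carries moves the number by more than the scatter, and bromo is accepted there with the lower number of the pair. Nothing available bears on the reason for this step, so the difference stands as an observation without an explanation.

As far as these compounds go, with only fluoro and bromo at this carbon, one step gives a direction for a single exchange and no trend across groups, so it remains open whether chloro or iodo would fall in line with bromo, or whether an amine or a methyl group would be accepted there at all. From the compounds shown here alone, it is also open whether the same exchange would give a step of similar size on the sugar carried by compound 2, and whether the lower number reflects anything beyond general cytotoxicity in these cells.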